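Adding a Nitro Group to an Anilino Analogue

This account rests on a few compounds, and the source may have more. Where it says the series, first, only, none or still open, it means among the compounds named here.

Compound 1, `CSc1nn(-c2ccc([N+](=O)[O-])cc2)c2nc(Nc3ccccc3)n(-c3ccccc3)c(=O)c12`, gives 26.6% in a functional assay on the whole organism (strain Wistar albino) for inhibition, with Rattus norvegicus as the target, read by paw edema, with a stated time of 3 h, at a dose of 25 mg/kg by the oral route; a lower number here means less inhibition, a higher number more inhibition at the dose given (going by the name of the read-out).
Compound 2, `O=c1c2c(Nc3ccccc3)nn(-c3ccc([N+](=O)[O-])cc3)c2nc(Nc2ccccc2)n1-c1ccccc1`, gives 14.1%.
Compound 3, `Cc1ccc(Nc2nn(-c3ccccc3)c3nc(Nc4ccccc4)n(-c4ccccc4)c(=O)c23)cc1`, gives 32.9%.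

Compound 3 sits within the scatter of compound 1 and beyond the scatter above compound 2. Compound 4, `Cc1ccc(Nc2nn(-c3ccc([N+](=O)[O-])cc3)c3nc(Nc4ccccc4)n(-c4ccccc4)c(=O)c23)cc1`, differs from compound 3 by nitro in place of hydrogen on an aromatic carbon. Among the measured compounds shown here, the only measured step, a number 12.5 percentage points lower from compound 1 to compound 2 (beyond the scatter), concerns a different exchange and does not touch a nitro group, so no measured step bears directly on this change. Compounds 1 and 2 both carry the nitro group while compound 3 does not, but they also differ elsewhere, so their values show nothing separate about it. The expected step is therefore small, a number 2.9 percentage points lower from compound 3 to compound 4 (within the scatter), no further than the scatter. Compound 4 is estimated at 30%, between 15% and 45%.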

Compound 4, a percentage reported as inhibition, in the whole organism at one dose (the size of the read-out at that dose, not a potency): 30.2%
The estimate for compound 4 lay 0.2 percentage points below the measured number; measured number inside the range.
By their numbers in this assay, from the lowest: compound 2; then compounds 1, 4 and 3 (each within the scatter of the next).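

In this assay, adding the nitro group gives a number 2.7 percentage points lower from compound 3 to compound 4 (within the scatter), so phenyl to 4-nitrophenyl shows no clear effect on this read-out. The nitro group does not fix the number on its own: among the nitro compounds, methyl in place of hydrogen gives a number 16.1 percentage points higher from compound 2 to compound 4 (beyond the scatter), whereas (4-methylphenyl)amino in place of methylsulfanyl gives a number 3.6 percentage points higher from compound 1 to compound 4 (within the scatter), a change that stays small. No measurement offers an explanation for these numbers.

As far as these compounds go, whether an amine or a carboxylic acid in the nitro group's place would shift the number remains open.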